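This account rests on a few compounds, and the source may have more. Where it says the series, first, only, none or still open, it means among the compounds named here.

Of the compounds shown here, three of a shared core have been tested in a functional assay on DLD-1 cells (Homo sapiens) for antiproliferative activity, read by CellTiter-Glo, with a stated time of 72 h; a higher number here means a weaker inhibitor, a lower number a stronger inhibitor. Compound 1, `CC1CCN(C2CCN(S(=O)(=O)c3ccccc3-c3ccc(C(F)(F)F)cc3)CC2)CC1`, gives 122 nM. Compound 2, `Cc1cc(C)c(S(=O)(=O)N2CCC(N3CCC(Cc4ccc(F)cc4)CC3)CC2)c(C)c1`, gives 18 nM. Compound 3, `CC1CCN(C2CCN(C(=O)c3ccc(OC(F)(F)F)cc3)CC2)CC1`, gives 426 nM. Among these three numbers compound 2 stands lowest, and its distance to each of the other two is beyond the usual scatter, so it is the strongest inhibitor of the set.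

The next compound takes compound 2 as its starting point. Compound 4, `Cc1cc(C)c(S(=O)(=O)N2CCC(N3CCCCC3)CC2)c(C)c1`, differs from it in a single place: hydrogen in place of 4-fluorobenzyl on a saturated ring carbon. The group that leaves is the largest side group on compound 2, and nothing is put in its place apart from a hydrogen atom. Among the compounds with values here, no pair of measured compounds shows this exact change, so the size of the step is open. Because compound 2 gives 18 nM and is the strongest of the set, the expectation is that taking away a whole side group weakens it, giving an expected step of an 8.3-fold higher number from compound 2 to compound 4 (0.92 log units; beyond the scatter) in this assay. Compound 4 is therefore estimated at 150 nM, within a range from 40 nM to 600 nM.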

Compound 4, half-maximal inhibitory concentration: 2200 nM
Compound 4: middle estimate off by 15-fold (1.17 log units), on the low side, and the stated range ends below it.
By their numbers in this assay, from the lowest: compound 2; then compound 1; then compound 3; then compound 4.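

Taking away the 4-fluorobenzyl group and leaving only a hydrogen atom gives, in this assay, a 120-fold higher number from compound 2 to compound 4 (2.09 log units; beyond the scatter), a large step well beyond the scatter. Within the data shown here, this is the first direct view of this saturated ring carbon, three ring bonds from the ring nitrogen: what it carries matters greatly here, and much of the strength of compound 2 depends on the 4-fluorobenzyl group being present. Nothing measured here accounts for the size of this loss.

The compounds shown leave open how much of the step belongs to the aromatic ring and how much to the fluorine, which a plain benzyl group would help to separate. They also leave open whether a small methyl group, or a longer chain ending in the same ring, would keep the strength of compound 2.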